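This account rests on a few compounds, and the source may have more. Where it says the series, first, only, none or still open, it means among the compounds named here.

Measured compounds:
compound 1 `COc1ccc(F)cc1CNCCCNc1ccnc2cc(Oc3ccc(F)cc3)ccc12` — 9.28
compound 2 `Fc1ccc(Oc2ccc3c(NCCCNCc4ccco4)ccnc3c2)cc1` — 9.28
compound 3 `COc1cccc(CNCCCNc2ccnc3cc(Cc4ccc(C#N)cc4)ccc23)c1O` — 9.47

All three numbers come from a physicochemical assay for acid dissociation. Compound 1 stands level with compound 2, the two together at the low end of the three; compound 3 sits higher by a gap that is still within the scatter, so the whole set reads as one level.

Within the data shown here, the only single-point step is from compound 1 to compound 2: no change at the digits printed from compound 1 to compound 2 (within the scatter), furan-2-yl in place of 5-fluoro-2-methoxyphenyl on a saturated chain carbon bound to an amine nitrogen. Swapping the group on the benzyl carbon of the chain amine left the proton unchanged.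

Compound 4 `COc1ccc(F)cc1CNCCCNc1ccnc2cc(Cc3cc(C)cc(C)c3)ccc12` is the next step from compound 1. It changes the core instead: 3,5-dimethylbenzyl in place of 4-fluorophenoxy on an aromatic carbon. Among the measured compounds shown here, no measured pair isolates this change; compound 3 carries a benzyl on the core but also a different chain benzyl, so its value gives only a loose hint that a core benzyl does not move the number beyond the scatter. With the chain amine untouched, no step beyond the scatter is expected for a number 0.07 log units higher from compound 1 to compound 4 (within the scatter). Compound 4 is therefore estimated at 9.35, between 9 and 9.7.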

Compound 4, acid dissociation constant: 9.47
The estimate for compound 4 lay 0.12 log units below the measured number; low and high end bracket the measured number.
By their numbers in this assay, from the lowest: compounds 1, 2, 3 and 4 (each within the scatter of the next).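

In this assay, the position on the core now has a reading of its own from a pair differing in one place: a number 0.19 log units higher from compound 1 to compound 4 (within the scatter), with 3,5-dimethylbenzyl in place of 4-fluorophenoxy on an aromatic carbon. Among these compounds, the only earlier step, no change at the digits printed from compound 1 to compound 2 (within the scatter), concerned the group on the chain, so a change at each of these two places on compound 1 has now been read, and neither step goes beyond the scatter. At this position the exchange takes out an oxygen and a fluorine and a hydrogen-bond acceptor, and there is no information on why the number stays within the scatter.

All the compounds shown keep the same chain with its amine, so it remains open whether a longer chain or an amide in place of that amine would give a step beyond the scatter. On these data alone, it also remains open whether a group of another kind on the same aromatic carbon, such as a carboxylic acid or a dimethylamino group, would leave the number within the scatter of compound 1.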